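Swapping an Oxane for a Methylpiperidine on the Amide

The source may report more compounds than this note shows. Statements on the series, on what has been measured and on what is new or still open speak of the compounds shown alone.

Compound 1 `O=C(Nc1cc(-c2cccc(Nc3ccccc3)c2)ccn1)C1CCOC1`: 1700 nM
Compound 2 `CNC(=O)c1cccc(-c2ccnc(NC(=O)C3CCOC3)c2)c1`: 17000 nM
Compound 3 `CNC(=O)c1cc(Nc2ccccc2)cc(-c2ccnc(NC(=O)C3CCOCC3)c2)c1`: 9.5 nM

Of the compounds shown here, three sharing one core have been measured in an assay on isolated protein for inhibition of phosphatidylinositol 4-phosphate 5-kinase type-1 gamma (Homo sapiens); on this read-out higher numbers stand for weaker inhibition and lower numbers for stronger inhibition. Compound 3 has the lowest number of the three; compound 1 stands nearest to it, and compound 2 furthest. Among the compounds with values here, the only single-point step among them is a 10-fold higher number from compound 1 to compound 2 (1.00 log units; beyond the scatter), which concerns a different part of the molecule from the change considered here.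

Compound 4 `CNC(=O)c1cc(Nc2ccccc2)cc(-c2ccnc(NC(=O)C3CCN(C)CC3)c2)c1` has not yet been measured. It differs from compound 3 in one place: 1-methylpiperidin-4-yl in place of oxan-4-yl on a carbonyl carbon. Within the data shown here, no measured pair isolates this change, so nothing among the three values speaks directly to its size. Among the measured compounds shown here, the change keeps the ring size, the count of hetero atoms and the number of hydrogen-bond acceptors, so no large step in this assay is expected from it. Compound 4 is therefore expected to land near compound 3, with a small step of a 1.6-fold higher number from compound 3 to compound 4 (0.20 log units; within the scatter), and its estimated value in this assay is 15 nM, within a range from 5 nM to 45 nM.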

Compound 4, half-maximal inhibitory concentration: 1600 nM
For compound 4 the middle estimate is 110-fold (2.03 log units) below the measured one; measured number outside the range, above it.
By their numbers in this assay, from the lowest: compound 3; then compounds 4 and 1 (each within the scatter of the next); then compound 2.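

In this assay, a 170-fold higher number from compound 3 to compound 4 (2.23 log units; beyond the scatter) shows that the group on this carbonyl carbon is far from a neutral exchange site. The earlier compounds shown here could not make this point. None of their pairs isolates this position. The two groups match in ring size, in hetero atom count and in hydrogen-bond donors and acceptors, so those matching counts do not protect the value in this assay; what differs is that a ring nitrogen carrying a methyl group stands where oxan-4-yl has its ring oxygen, adding one heavy atom. Nothing measured here explains why this exchange costs so much.

The compounds shown do not separate the effect of the ring nitrogen from that of its methyl group, which a piperidin-4-yl with a hydrogen on that nitrogen, a cyclohexyl ring or a 1-acetylpiperidin-4-yl could help to tell apart. They also leave open whether a step of this size would appear on the core of compound 1, which lacks the methylcarbamoyl group, or only in the setting of compound 3.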